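Removing a Ring Methyl: What Compound 4 Might Clear

The source may hold more compounds than are shown below. What is called first, only, known or untested is meant among the compounds shown, and "the series" means these compounds.

Compound 1 `C[C@]1(O)C[C@@](c2cccc(C(F)(F)F)c2)([C@H](O)c2ccccn2)C1` was measured in an ADME assay on liver for metabolic stability, with Liver microsome (Homo sapiens) as the target, read by LC-MS, using microsomes, with a stated time of 5 h (on this read-out lower numbers stand for slow clearance and higher numbers for fast clearance), where compound 1 gives 150 mL/min/kg. Among the three compounds measured, compound 1 stands second highest. Its nearest neighbour is compound 3 `C[C@]1(O)C[C@@](c2cccc(OC(F)(F)F)c2)([C@H](O)c2ccccn2)C1`, which in this assay gives 167 mL/min/kg; the step of a 1.1-fold higher number from compound 1 to compound 3 (0.05 log units; within the scatter) lies within the scatter. Furthest from it is compound 2 `O[C@H](c1ccccn1)[C@]1(c2ccnc(C(F)(F)F)c2)C[C@H](O)C1`, which in this assay gives 33.3 mL/min/kg, a number that sits beyond the scatter below that of compound 1.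

Compound 4 `O[C@H](c1ccccn1)[C@]1(c2cccc(C(F)(F)F)c2)C[C@@H](O)C1` differs from compound 1 in one place: hydrogen in place of methyl on a saturated ring carbon. Going by the values given here, the only measured step between single-point neighbours, the one from compound 1 to compound 3, concerns a trifluoromethoxy in place of trifluoromethyl on an aromatic carbon, not a change on the four-membered ring, and it was small. Among the compounds with values here, no measured pair shows what removing a methyl from a saturated ring carbon does here. With nothing in the data to point either way, compound 4 is expected to give a number close to that of compound 1, so the step of a 1.3-fold lower number from compound 1 to compound 4 (0.10 log units; within the scatter) is expected to stay within the scatter. Compound 4 is therefore estimated at 120 mL/min/kg, with a range from 55 mL/min/kg to 250 mL/min/kg.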

Compound 4, clearance: 50 mL/min/kg
Beside the measured number, compound 4's estimate is 2.4-fold (0.38 log units) above it; the measured number lies below the stated range.
By their numbers in this assay, from the lowest: compounds 2 and 4 (each within the scatter of the next); then compounds 1 and 3 (each within the scatter of the next).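

In this assay, the saturated ring carbon of the four-membered ring proves responsive to a single change: hydrogen in place of methyl there gives a 3.0-fold lower number from compound 1 to compound 4 (0.48 log units; beyond the scatter). The only single-place step available earlier, a 1.1-fold higher number from compound 1 to compound 3 (0.05 log units; within the scatter), concerned trifluoromethoxy in place of trifluoromethyl on an aromatic carbon and stayed within the scatter, so this is the first single change shown to carry the number beyond it. Nothing at hand explains the size or direction of this step.

This finding rests on one pair, and the compounds shown leave open whether the position answers only to the removal of the methyl or also to what is placed there, such as an ethyl group, a fluorine atom or a methoxy group on the same ring carbon. They also leave open whether hydrogen in place of methyl would give a step of similar size with trifluoromethoxy on the aromatic carbon, as in compound 3.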